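The source may report more compounds than this note shows. Statements on the series, on what has been measured and on what is new or still open speak of the compounds shown alone.

Measured so far in an ADME assay on Raji cells (Homo sapiens) for cytotoxicity, read by luminescence, with a stated time of 72 h; on this read-out lower numbers stand for an effect already at smaller amounts and higher numbers for an effect only at larger amounts of compound:
Compound 1 `C=Cc1cccc(-c2[nH]c3cc(OC)ccc3c(=O)c2C(=O)OCC)c1`: compound 1 gives > 21500 nM, which is a limit of the assay and not a number.
Compound 2 `CCOC(=O)c1c(-c2cccc(OCC)c2)[nH]c2cc(OC)ccc2c1=O`: compound 2 gives > 21500 nM, again only a limit.
Compound 3 `CCOC(=O)c1c(-c2cccc(Br)c2)[nH]c2cc(OC)ccc2c1=O`: compound 3 gives > 21500 nM, also a limit.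

All three values sit together at the limit of > 21500 nM in this assay, at which 3 of the 3 values shown sit, so compound 2 cannot be placed higher or lower than compounds 1 and 3. The steps a step that the two limits leave unreadable from compound 1 to compound 2, a step that the two limits leave unreadable from compound 1 to compound 3 and a step that the two limits leave unreadable from compound 2 to compound 3 all change the same position but remain unreadable in size. Compound 4 `CCOC(=O)c1c(-c2cccc(N(C)C)c2)[nH]c2cc(OC)ccc2c1=O` differs from compound 2 by dimethylamino in place of ethoxy on an aromatic carbon. The unreadable steps give no direction, so compound 4 is expected to stay near the limit, with an expected step that the limit leaves unreadable from compound 2 to compound 4. The estimate for compound 4 is 30000 nM, from 10000 nM to 100000 nM.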

Compound 4, half-maximal effective concentration: > 21500 nM
Compound 4 ended at the assay's limit; the forecaster's own chance of this, stated with the estimate: 75%; the middle value is on the limit's open side.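

In this assay compound 4 gives > 21500 nM as a limit and not a number. Going by these compounds alone, compounds 1, 2, 3 and 4 all sit at this limit, so no step between them can be read. As far as these compounds go, whether vinyl, ethoxy, bromo and dimethylamino differ at all in this assay stays open.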